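Biphenyl carboxylic acid sulfonamides: swapping the distal aryl group

The source may hold more compounds than are shown below. What is called first, only, known or untested is meant among the compounds shown, and "the series" means these compounds.

Measured so far:
compound 1, `CCCCCCCCS(=O)(=O)Nc1ccc(-c2ccc(Cl)cc2)cc1C(=O)O`, 9200 nM
compound 2, `CCCCCCCCS(=O)(=O)Nc1ccc(-c2ccccc2O)cc1C(=O)O`, 61700 nM

In an assay on mitochondria (strain BALB/c) for inhibition of glycerol-3-phosphate acyltransferase 1, mitochondrial (Mus musculus), read by scintillation counting, with a stated time of 10 min (on this read-out higher numbers stand for weaker inhibition and lower numbers for stronger inhibition), compound 2 stands as the higher of the two numbers measured, above compound 1 by a 6.7-fold higher number from compound 1 to compound 2 (0.83 log units; beyond the scatter). Compound 3, `CCCCCCCCS(=O)(=O)Nc1ccc(CCc2ccc(OC)cc2)cc1C(=O)O`, differs from compound 2 by 2-(4-methoxyphenyl)ethyl in place of 2-hydroxyphenyl on an aromatic carbon. Going by the values given here, no measured step covers this exact change; the only step at hand, a 6.7-fold higher number from compound 1 to compound 2 (0.83 log units; beyond the scatter), shows that altering the aryl group moves the number in this assay by a modest amount. For compound 3 a modest step back down is therefore expected, a 2.5-fold lower number from compound 2 to compound 3 (0.39 log units; beyond the scatter), giving an estimated 25000 nM with a range from 6000 nM to 90000 nM.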

Compound 3, half-maximal inhibitory concentration: 26300 nM
The estimate for compound 3 lay 1.1-fold (0.02 log units) below the measured number, and the stated range covers the measured number.
By their numbers in this assay, from the lowest: compound 1; then compound 3; then compound 2.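

In this assay, 2-(4-methoxyphenyl)ethyl in place of 2-hydroxyphenyl gives a 2.3-fold lower number from compound 2 to compound 3 (0.37 log units; beyond the scatter) at this aromatic carbon, and in place of 4-chlorophenyl it gives a 2.9-fold higher number from compound 1 to compound 3 (0.46 log units; beyond the scatter) here. The number for the aryl group carried on an ethyl link therefore falls between the two directly attached aryl groups, so this position accepts the larger group without moving past either. Nothing measured here bears on why these numbers differ.

From the compounds shown here alone, the ethyl link and the methoxy group enter together, so their separate contributions stay open. A 2-(4-chlorophenyl)ethyl group would help separate them, while an amine on the distal ring remains untested in what is shown.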